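The compounds below may be only part of what the source reports. "The series", "measured", "known", "first", "only" and "open" are said of these compounds alone.

Values in an ADME assay on HEK293 cells (Homo sapiens) for cytotoxicity, with a stated time of 72 h; on this read-out lower numbers stand for an effect already at smaller amounts and higher numbers for an effect only at larger amounts of compound:

- compound 1 `Cc1cc(NC(=O)Nc2ccccc2OC(F)(F)F)c2ccccc2n1`: > 25000 nM (a limit)
- compound 2 `Cc1cc(NC(=O)Nc2ccc(Cl)c(Cl)c2)c2ccccc2n1`: > 25000 nM (a limit)
- compound 3 `CSc1ccc(NC(=O)Nc2cc(C)nc3ccccc23)cc1`: 24000 nM
- compound 4 `CC(=O)c1ccc(NC(=O)Nc2cc(C)nc3ccccc23)cc1`: not yet measured

Among the compounds with values here, compound 3 gives 24000 nM, the only actual number in the set. The reading for compound 1 is a limit and not a number, and the same holds for compound 2. The set as a whole therefore sits at or close to the limit of > 25000 nM in this assay, at which 2 of the 3 values shown sit.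

The next compound changes one substituent: acetyl in place of methylsulfanyl on an aromatic carbon. Within the data shown here, no pair of measured compounds differs in one place only, so the series offers no measured step to draw on. Among the measured compounds shown here, the only guide is compound 3 at 24000 nM. No shift beyond the scatter is expected in this assay, in either direction. The expected size of the change is a 1.0-fold higher number from compound 3 to compound 4 (0.02 log units; within the scatter). A limit reading would be no surprise here. For compound 4 the estimated value is 25000 nM, with an expected range of 14000 nM to 40000 nM.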

Compound 4, half-maximal effective concentration: > 25000 nM
Compound 4: only a limit was reported; the forecaster's own chance of this, stated with the estimate: 65%; the middle value sits exactly at the limit.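

In this assay compound 4 gives > 25000 nM, which is a limit and not a number. Within the data shown here, at this place, on an aromatic carbon para to a large group, acetyl in place of methylsulfanyl gives an at least 1.0-fold higher number from compound 3 to compound 4 (0.01 log units; that floor lies within the scatter), so the only single-place step shows no shift beyond the scatter. Neither group at this place moves the series away from its ceiling on this read-out: the limit of > 25000 nM in this assay, at which 3 of the 4 values shown sit.

How far compound 4 actually lies from compound 3 cannot be read, since its reading has no upper end. Also open, on these data alone, is whether an amine, a carboxylic acid or a longer chain at this place would give a number clearly under the limit in this assay.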